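A few compounds are considered here, and "the series" means these few. Any claim that something is new, unique, unknown or untested is made for them only; others in the source may bear on it.

Measured compounds:
- compound 1, `COc1ccc(/C(=N/NC(=O)NCCCC(C)Nc2cc(OC)cc3cccnc23)c2ccccc2)cc1`: >= 250000 nM
- compound 2, `COc1cc(NC(C)CCCNC(=O)NNC(=O)Nc2ccc(Cl)c(C(F)(F)F)c2)c2ncccc2c1`: 19000 nM
- compound 3, `CCOC(=O)N(C)C(c1ccccc1)c1ccccc1`: 105000 nM

In a functional assay on MOLT-4 cells (Homo sapiens) for inhibition, read by MTT assay, with a stated time of 4 days (a higher number here means a weaker inhibitor, a lower number a stronger inhibitor), compound 2 gives 19000 nM. Compound 3 gives 105000 nM in this assay, a higher number, and the gap between these two lies beyond the usual scatter, so of the two compounds with a number compound 2 is the stronger inhibitor. For compound 1 this assay reports only a limit, >= 250000 nM; this is the limit of >= 250000 nM in this assay, at which 1 of the 3 values shown sits, and no number is attached to it.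

Compound 4, `COc1cc(NC(C)CCCNC(=O)NNC(=O)NC(CO)(CO)CO)c2ncccc2c1`, has not yet been measured in this assay. It shares the core of compound 2 and differs from it in one place: 2-hydroxy-1,1-bis(hydroxymethyl)ethyl in place of 4-chloro-3-(trifluoromethyl)phenyl on an amide-type nitrogen. Among the measured compounds shown here, no step between two measured compounds matches this change, so the direction and size must be judged from compound 2 alone.

Compound 4 is expected to be a weaker inhibitor than compound 2 in this assay, a step from compound 2 to compound 4 of about a 4.2-fold higher number from compound 2 to compound 4 (0.62 log units; beyond the scatter), well beyond the scatter. On that basis compound 4 is estimated at 80000 nM in this assay, within a range from 25000 nM to 250000 nM; there is a fair chance that this assay returns only a limit for compound 4.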

Compound 4, half-maximal inhibitory concentration: > 250000 nM
Compound 4: only a limit was reported (the forecaster's own chance of this, stated with the estimate: 35%); middle value at least 3.1-fold (0.49 log units) from the limit.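

In this assay, the first step read at this position is large: 2-hydroxy-1,1-bis(hydroxymethyl)ethyl in place of 4-chloro-3-(trifluoromethyl)phenyl on the amide-type nitrogen gives an at least 13-fold higher number from compound 2 to compound 4 (1.11 log units; beyond the scatter). Among the compounds shown here, this shows that the group on this nitrogen decides whether the assay returns a number at all for this pair, something the earlier compounds could not show, as none of them differed from another in one place. The result for compound 4 is a limit of the assay and not a number: the limit of > 250000 nM in this assay, at which 1 of the 4 values shown sits.

From the compounds shown here alone, the pair cannot separate the loss of the six-membered aromatic ring from the arrival of the hydroxyl groups, since both come with the same change, and it remains open whether a plain phenyl, or a phenyl carrying only the chlorine or only the trifluoromethyl, would hold the value of compound 2. Also open, going by these compounds, is whether a tert-butyl group, with the branched carbon frame but no hydroxyl groups, or a cyclohexyl ring on this nitrogen would return a number in this assay.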